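Anilide series: trifluoromethyl for chloro on the amide aryl

This account rests on a few compounds, and the source may have more. Where it says the series, first, only, none or still open, it means among the compounds named here.

Among the compounds with values here, compound 3 `O=C(CSc1nc(Nc2ccccc2)c2ccccc2n1)Nc1ccc(Cl)cc1` gives 40400 nM in a functional assay on MGC-803 cells (Homo sapiens) for inhibition, read by MTT assay, with a stated time of 72 h (on this read-out lower numbers stand for stronger inhibition and higher numbers for weaker inhibition), the highest of the three numbers measured so far. Compound 1 `O=C(CSc1nc(Nc2ccccc2)c2ccccc2n1)Nc1ccccc1F` gives 10700 nM and compound 2 `O=C(CSc1nc(Nc2ccccc2)c2ccccc2n1)Nc1ccccc1Br` gives 18600 nM; the steps toward compound 3 are a 3.8-fold higher number from compound 1 to compound 3 (0.58 log units; beyond the scatter) and a 2.2-fold higher number from compound 2 to compound 3 (0.34 log units; beyond the scatter), both beyond the scatter, whereas a 1.7-fold higher number from compound 1 to compound 2 (0.24 log units; within the scatter) stays within it. Compound 4 `O=C(CSc1nc(Nc2ccccc2)c2ccccc2n1)Nc1ccc(C(F)(F)F)cc1` differs from compound 3 by trifluoromethyl in place of chloro on an aromatic carbon. Within the data shown here, no measured step exchanges one group for another at that same carbon. Among the measured compounds shown here, the only like-for-like halogen exchange in the set, a 1.7-fold higher number from compound 1 to compound 2 (0.24 log units; within the scatter), was within the scatter, and the larger steps came from exchanging 2-fluorophenyl or 2-bromophenyl for 4-chlorophenyl rather than from the identity of the substituent alone. The step from compound 3 to compound 4 in this assay is therefore expected to be small, a 1.1-fold higher number from compound 3 to compound 4 (0.05 log units; within the scatter), with no direction that can be called beyond the scatter. Compound 4 is estimated at 45000 nM, within a range of 15000 nM to 130000 nM.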

Compound 4, half-maximal inhibitory concentration: 8670 nM
For compound 4 the middle estimate is 5.2-fold (0.72 log units) above the measured one, outside the stated range (below it).
By their numbers in this assay, from the lowest: compounds 4, 1 and 2 (each within the scatter of the next, the first and the last beyond it); then compound 3.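

In this assay, the change from 4-chlorophenyl to 4-(trifluoromethyl)phenyl gives a step beyond the scatter (a 4.7-fold lower number from compound 3 to compound 4 (0.67 log units; beyond the scatter)), so the group on this aromatic carbon, para to a large group, matters by itself, which the earlier halogen exchange (a 1.7-fold higher number from compound 1 to compound 2 (0.24 log units; within the scatter)) did not show. The 4-substituted anilides also no longer read as uniformly weaker than the 2-halo anilides: compound 4 stands within the scatter of compound 1 (a 1.2-fold lower number from compound 1 to compound 4 (0.09 log units; within the scatter)) and beyond it against compound 2 (a 2.1-fold lower number from compound 2 to compound 4 (0.33 log units; beyond the scatter)). Nothing measured here accounts for the difference between chloro and trifluoromethyl.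

Within the data shown here, with only two groups compared on this carbon, no trend across substituents can be drawn. An amine, a carboxylic acid or a methoxy group there would test whether the gain extends beyond trifluoromethyl.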